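The compounds below may be only part of what the source reports. "The series", "measured", "known", "first", "only" and "open" are said of these compounds alone.

Among the measured compounds shown here, in a functional assay on K562 cells (Homo sapiens) for cytotoxicity, read by MTT assay, with a stated time of 3 days (a higher number here means a weaker inhibitor, a lower number a stronger inhibitor), compound 1 `N#Cc1c(O)nc(SCc2nc3ccccc3[nH]2)nc1-c1ccccc1` gives 4.63 nM, while compound 2 `N#Cc1c(NN)nc(SCc2nc3ccccc3[nH]2)nc1-c1ccccc1` gives 14.7 nM, the higher of the two numbers so far. For the measured compounds named here, the only measured step is a 3.2-fold higher number from compound 1 to compound 2 (0.50 log units; beyond the scatter), a modest change that puts aminoamino in place of hydroxy on an aromatic carbon. Compound 3 `N#Cc1c(Nc2ccccc2)nc(SCc2nc3ccccc3[nH]2)nc1-c1ccccc1` changes that same group again, from aminoamino to anilino, as phenyl in place of amino on a nitrogen on an aromatic ring. In words, this is phenyl in place of amino on a nitrogen on an aromatic ring. Going by the values given here, one modest step is thin evidence, and no measured compound carries this phenyl group, so the direction cannot be read with confidence. The expected change in this assay is therefore small, estimated as a 1.4-fold higher number from compound 2 to compound 3 (0.13 log units; within the scatter). For compound 3 the estimate is 20 nM, with an expected range from 5 nM to 80 nM.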

Compound 3, half-maximal inhibitory concentration: 3.2 nM
Estimate against measurement, compound 3: 6.3-fold (0.80 log units) above; the measured number lies below the stated range.
By their numbers in this assay, from the lowest: compounds 3 and 1 (each within the scatter of the next); then compound 2.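

Among the compounds shown here, the position on the shared core accepts a much larger group than the earlier compounds showed: in this assay, phenyl in place of amino on the nitrogen gives a 4.6-fold lower number from compound 2 to compound 3 (0.66 log units; beyond the scatter). Compound 2 therefore does not show that every nitrogen-linked group here raises the number, and anilino and hydroxy cannot be told apart, with a 1.4-fold lower number from compound 1 to compound 3 (0.16 log units; within the scatter). Nothing measured here accounts for the effect of this change.

As far as these compounds go, it remains open whether the new number depends on an aromatic ring at all, or whether a simple methyl or ethyl chain on the same nitrogen would give a similar result. Also open, from the compounds shown here alone, is how a chlorine or methoxy group on the phenyl ring would shift the number in this assay.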